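Methyl to methoxy on two different ketone cores

The source may hold more compounds than are shown below. What is called first, only, known or untested is meant among the compounds shown, and "the series" means these compounds.

Measured compounds:
compound 1, `Cc1cccc(/C=C2\Cc3ccccc3C2=O)c1`, 50400 nM
compound 2, `COc1cccc(/C=C2\Cc3ccccc3C2=O)c1`, 217000 nM
compound 3, `Cc1ccc(/C=C2\CCCCCC2=O)cc1`, > 500000 nM

In a functional assay on L1210 cells (Mus musculus) for inhibition (a higher number here means a weaker inhibitor, a lower number a stronger inhibitor), compound 1 gives 50400 nM and compound 2 gives 217000 nM. The two differ by methoxy in place of methyl on an aromatic carbon, and the step is a 4.3-fold higher number from compound 1 to compound 2 (0.63 log units; beyond the scatter). For compound 3 the value > 500000 nM is only a limit of this assay, not a number, as marked by the limit of > 500000 nM in this assay, at which 1 of the 3 values shown sits. The difference between the core of compound 1 and the core of compound 3 is not broken down here.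

Compound 4, `COc1ccc(/C=C2\CCCCCC2=O)cc1`, is not yet measured. It differs from compound 3 by methoxy in place of methyl on an aromatic carbon. This is the same kind of change as from compound 1 to compound 2, though the place is not the same: there the group sits meta to a large group, here para to a group of 9 heavy atoms. Since the earlier step weakened inhibition, and compound 3 already sits at the limit > 500000 nM, compound 4 is expected at or beyond that limit, with an estimated step that the limit leaves unreadable from compound 3 to compound 4. The estimate for compound 4 in this assay is 1000000 nM, between 500000 nM and 3000000 nM, most likely reported only as a limit.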

Compound 4, half-maximal inhibitory concentration: 306000 nM
Beside the measured number, compound 4's estimate is 3.3-fold (0.51 log units) above it, outside the stated range (below it).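

In this assay, methoxy in place of methyl gives an at least 1.6-fold lower number from compound 3 to compound 4 (0.21 log units; that floor lies within the scatter), so the effect of this change on the core of compound 1 cannot simply be assumed to hold on the core of compound 3: the same change on two cores in this assay, a 4.3-fold higher number (0.63 log units; beyond the scatter) from compound 1 to compound 2 and an at least 1.6-fold lower number (0.21 log units; that floor lies within the scatter) from compound 3 to compound 4, at least 7.0-fold (0.84 log units) apart, beyond the scatter of two such steps

From the compounds shown here alone, compound 3 has only a limit of the assay, > 500000 nM, not a number, and the true size of this step remains unknown. The two pairs differ both in their core and in where the group sits on the aromatic ring, and these compounds cannot separate the two differences, so they do not show which one matters.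

Going by these compounds, it remains open how methyl and methoxy would compare on each core if the group sat in the same place on the aromatic ring. On these data alone, it is also open how other groups in that place, such as an amine, a carboxylic acid or a longer chain, would behave on these two cores.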